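Swapping bromine for chlorine on a thione herbicide scaffold

The source may report more compounds than this note shows. Statements on the series, on what has been measured and on what is new or still open speak of the compounds shown alone.

Of the compounds shown here, two of a shared core have been tested. Compound 1, `S=c1n(-c2ccc(OCc3ccc(Cl)cc3)cc2)c(=S)n2n1CCCC2`, carries an extended side group on its aromatic ring, while compound 2, `S=c1n(-c2ccc(Br)cc2)c(=S)n2n1CCCC2`, carries only a bromo group there. In a functional assay on the whole organism for inhibition, with Echinochloa esculenta as the target (on this read-out higher numbers stand for weaker inhibition and lower numbers for stronger inhibition), compound 1 gives 871 nM, whereas compound 2 gives 66.1 nM. Of the two numbers, that of compound 2 is the lower one, and the number of compound 1 stands well above it, a gap beyond the usual scatter, so compound 2 is the stronger inhibitor in this pair.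

Compound 3, `S=c1n(-c2ccc(Cl)cc2)c(=S)n2n1CCCC2`, has not yet been measured. It differs from compound 2 in one place: chloro in place of bromo on an aromatic carbon. Among the compounds with values here, both groups are single halogen atoms, and no pair of compounds in this set shows what such a swap does. The step of a 1.4-fold higher number from compound 2 to compound 3 (0.16 log units; within the scatter) is therefore expected to be small, at most a modest weakening, and possibly nothing beyond the scatter. Compound 3 is expected to give about 95 nM in this assay, with a likely range from 35 nM to 260 nM.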

Compound 3, half-maximal inhibitory concentration: 89.1 nM
The estimate for compound 3 lay 1.1-fold (0.03 log units) above the measured number; the measured number falls inside the stated range.
By their numbers in this assay, from the lowest: compounds 2 and 3 (each within the scatter of the next); then compound 1.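

In this assay, putting chloro in place of bromo on this aromatic carbon gives a 1.3-fold higher number from compound 2 to compound 3 (0.13 log units; within the scatter), so the read-out does not separate these two halogens at this place. Within the data shown here, until now, no pair in the set differed by one halogen atom alone; this pair shows that a bromine atom can leave and a chlorine atom can enter here with no step beyond the ordinary spread of repeated measurements. Nothing given here explains why the two compounds read alike, and no measurement of any property of the two halogens accompanies the result.

On these data alone, it remains open whether this carbon accepts groups other than these two halogens: fluoro, iodo, an amine or a carboxylic acid at the same place would each put that to the test, and each could show whether the match between compound 2 and compound 3 extends beyond this one swap. As far as these compounds go, it also remains open whether chloro and bromo would still match on a changed version of the shared core, or against a whole organism other than the one tested here.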